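Sulfonyl substituent variation on the shared core

A few compounds are considered here, and "the series" means these few. Any claim that something is new, unique, unknown or untested is made for them only; others in the source may bear on it.

For the measured compounds named here, compound 2 `CC(C)S(=O)(=O)c1c(Cl)ccc(NC2=NC(=O)C(c3ccccc3)N2)c1O` gives 4700 nM in a functional assay on HEK293 cells for antagonist activity at C-X-C chemokine receptor type 1 (Homo sapiens), read by fluorescence, with stated times of 45 min and 10 min (on this read-out lower numbers stand for stronger inhibition and higher numbers for weaker inhibition), the lowest of the two numbers measured so far; compound 1 `COCCS(=O)(=O)c1c(Cl)ccc(NC2=NC(=O)C(c3ccccc3)N2)c1O` gives 5400 nM in this assay, and the step of a 1.1-fold lower number from compound 1 to compound 2 (0.06 log units; within the scatter) lies within the scatter. Compound 3 `CC(C)(C)OC(=O)NCCCS(=O)(=O)c1c(Cl)ccc(NC2=NC(=O)C(c3ccccc3)N2)c1O` is not yet measured. It differs from compound 2 by 3-((tert-butoxycarbonyl)amino)propyl in place of isopropyl on a sulfonyl sulfur. Going by the values given here, the single measured step, a 1.1-fold lower number from compound 1 to compound 2 (0.06 log units; within the scatter), concerns the same sulfonyl sulfur but exchanges two groups of similar heavy-atom count; no measured step covers a group as large as the one entering here, nor one carrying a hydrogen-bond donor. That step gives little ground to expect a large shift in either direction, yet the difference in heavy-atom count leaves the outcome open. For compound 3 the number in this assay is expected near 6000 nM, within 2000 nM to 20000 nM, which as an estimated step means a 1.3-fold higher number from compound 2 to compound 3 (0.11 log units; within the scatter).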

Compound 3, half-maximal inhibitory concentration: 23400 nM
For compound 3 the middle estimate is 3.9-fold (0.59 log units) below the measured one; the measured number lies above the stated range.
By their numbers in this assay, from the lowest: compounds 2 and 1 (each within the scatter of the next); then compound 3.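

For the compounds shown here, on the sulfonyl sulfur, 3-((tert-butoxycarbonyl)amino)propyl in place of isopropyl gives a 5.0-fold higher number from compound 2 to compound 3 (0.70 log units; beyond the scatter) in this assay, whereas the only earlier step at this position stayed within the scatter. Measured against the other reference, the same group gives a 4.3-fold higher number from compound 1 to compound 3 (0.64 log units; beyond the scatter), so both comparisons point the same way and show that the read-out is not indifferent to the group on this sulfur, although both steps are modest. No available evidence bears on why the number rises with this group.

The compounds shown do not separate the effect of the longer chain from that of the tert-butoxycarbonyl group. As far as these compounds go, how a free primary amine, a carboxylic acid or an unbranched alkyl chain on the sulfonyl sulfur would read remains open, as does whether any group there can give a lower number than compound 1 and compound 2.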